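Adding a chloro to a weakly cytotoxic diaryl urea

The source may hold more compounds than are shown below. What is called first, only, known or untested is meant among the compounds shown, and "the series" means these compounds.

The measured compounds:
compound 1, `O=C(Nc1cccc(-n2cc(-c3ccncc3)c(-c3ccc(Cl)c(O)c3)n2)c1)Nc1cccc(C(F)(F)F)c1`: in a functional assay on HCT-15 cells (Homo sapiens) for inhibition, read by sulforhodamine B assay, with a stated time of 48 h (on this read-out lower numbers stand for higher toxicity in this test and higher numbers for lower toxicity in this test), compound 1 gives > 32500 nM, which is a limit of the assay and not a number.
compound 2, `COc1cc(-c2nn(-c3cccc(NC(=O)Nc4cccc(C(F)(F)F)c4)c3)cc2-c2ccncc2)ccc1Cl`: in this assay compound 2 gives 50000 nM.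

Among the measured compounds shown here, compound 2 holds the only number among the values shown; the other value is a limit (the limit of > 32500 nM in this assay, at which 1 of the 2 values shown sits). The step that the limit leaves unreadable from compound 1 to compound 2 is therefore not readable in size. Compound 3 `COc1cc(-c2nn(-c3cccc(NC(=O)Nc4ccc(Cl)c(C(F)(F)F)c4)c3)cc2-c2ccncc2)ccc1Cl` differs from compound 2 by chloro in place of hydrogen on an aromatic carbon. For the measured compounds named here, none of the measured steps touches this part of the structure, and the one measured step is itself unreadable, so no evidence is in hand for the effect of this change. Going by the values given here, the only anchor is the number for compound 2 itself. Compound 3 is thus expected to sit close to compound 2, and the step of a 1.1-fold lower number from compound 2 to compound 3 (0.05 log units; within the scatter) is estimated to stay within the scatter of this assay. The estimate for compound 3 in this assay is 45000 nM, with a range from 15000 nM to 100000 nM, and a real chance that only a limit is reported.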

Compound 3, concentration lethal to 50% of the cells: > 32500 nM
Compound 3 was reported as a limit; the forecaster's own chance of this, stated with the estimate: 40%; the middle value does not contradict the limit.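

In this assay compound 3 gives > 32500 nM, which is a limit of the assay and not a number, so no new step can be read between compound 2 and compound 3: the limit of > 32500 nM in this assay, at which 2 of the 3 values shown sit.

The compounds shown leave open what the change to 4-chloro-3-(trifluoromethyl)phenyl does in this assay, and whether compound 1, compound 2 and compound 3 differ at all.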